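Cyano for chloro near the top of a cytotoxicity assay

A few compounds are considered here, and "the series" means these few. Any claim that something is new, unique, unknown or untested is made for them only; others in the source may bear on it.

Four compounds are compared for how strongly they reduce the viability of a human cell line. Compound 1 `Cc1cc(NC(=O)c2ccc(Cl)cc2)ccc1NS(=O)(=O)C(F)(F)F` is the only one of the three measured ones with a plain number. In an ADME assay on HEK293 cells (Homo sapiens) for cytotoxicity, read by MTT assay, with a stated time of 48 h (on this read-out higher numbers stand for weaker inhibition and lower numbers for stronger inhibition), compound 1 gives 201000 nM. Compound 2 `Cc1cc(NC(=O)c2ccc(C#N)cc2)ccc1NS(=O)(=O)C(F)(F)F` differs from compound 1 in a single place: cyano in place of chloro on an aromatic carbon. For compound 2 this assay reports only a limit, > 250000 nM. The step of an at least 1.2-fold higher number from compound 1 to compound 2 (0.09 log units; that floor lies within the scatter) is thus a move from a measured number to the edge of what the assay can report.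

Compound 3 `COc1cc(NC(=O)c2ccc(Cl)cc2)ccc1NS(C)(=O)=O` has a different core; the difference between the two cores is not broken down here. For compound 3 this assay again reports only a limit, > 250000 nM. Compound 4 `COc1cc(NC(=O)c2ccc(C#N)cc2)ccc1NS(C)(=O)=O` is made from compound 3 by the same change: cyano in place of chloro on an aromatic carbon. The place of the change is the same, word for word, as for the change from compound 1 to compound 2, so it counts as the same change.

Because compound 3 already sits at the limit of > 250000 nM in this assay, at which 2 of the 3 values shown sit, compound 4 is expected to sit there as well. The step that the limit leaves unreadable from compound 3 to compound 4 is expected to be small, in line with the earlier step, which stayed within the scatter. Compound 4 is therefore estimated at about 300000 nM, with a likely range from 180000 nM to 600000 nM, and most probably reported only as a limit.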

Compound 4, half-maximal inhibitory concentration: > 250000 nM
Compound 4 ended at the assay's limit; the forecaster's own chance of this, stated with the estimate: 80%; the middle value lies beyond the limit too.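

Compound 3 and compound 4 each carry only a limit in this assay, not a number, and no step can be read between them. The same edge now holds most of the set: the limit of > 250000 nM in this assay, at which 3 of the 4 values shown sit.

The compounds shown leave open whether cyano in place of chloro changes the read-out at all, and how far past the limit compound 2, compound 3 and compound 4 lie.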